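Cytotoxicity notes: from compound 1 to compound 4

The source may hold more compounds than are shown below. What is called first, only, known or untested is meant among the compounds shown, and "the series" means these compounds.

Measured so far:
- compound 1 `c1ccc(-c2ccc(Cn3cncc3CNc3ccc(-c4nc5ccccc5s4)c(-c4ccccc4)c3)cc2)cc1` gives > 1000 nM as a limit
- compound 2 `CCOC(=O)c1ccc(NCc2cncn2Cc2ccc(-c3ccccc3)cc2)cc1-c1ccccc1` gives > 10000 nM as a limit
- compound 3 `COC(=O)c1ccc(NCc2cncn2Cc2ccc(-c3ccccc3)cc2)cc1-c1ccccc1` gives > 1000 nM as a limit

In a toxicity assay on NIH3T3 cells (Mus musculus) for cytotoxicity, read by resazurin assay (a lower number here means that less compound is needed, a higher number that more compound is needed for the effect), compound 1 stands only at a limit, > 1000 nM and no number. The other two results are limits as well, so compound 1 has no rank within the series.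

Compound 4 `CCc1ccc(Cn2cncc2CNc2ccc(-c3nc4ccccc4s3)c(-c3ccccc3)c2)cc1` differs from compound 1 in one place. The change ethyl in place of phenyl on an aromatic carbon is ethyl in place of phenyl on an aromatic carbon, para to a large group, or 4-phenylphenyl to 4-ethylphenyl.

Three measured steps exist, and none touches this place. They are a step that the two limits leave unreadable from compound 1 to compound 2 and a step that the two limits leave unreadable from compound 1 to compound 3 and also a step that the two limits leave unreadable from compound 2 to compound 3 with no size to carry over. The estimated step that the limit leaves unreadable from compound 1 to compound 4 is therefore only a rough expectation, with no direction read from the data. For compound 4 the expected value in this assay is 3000 nM with 1000 nM to 15000 nM as the estimated range, and another limit is the likeliest report.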

Compound 4, half-maximal effective concentration: > 1000 nM
Compound 4: no number, only a limit; the forecaster's own chance of this, stated with the estimate: 75%; the middle value lies beyond the limit too.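

Compound 1 and compound 4 both stand only at limits in this assay, so the step between them cannot be read. The compounds shown leave open whether changing 4-phenylphenyl to 4-ethylphenyl shifts the concentration needed at all; every value shown is a limit.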